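Fluoro in place of hydrogen on the shared core

The source may hold more compounds than are shown below. What is called first, only, known or untested is meant among the compounds shown, and "the series" means these compounds.

Among the compounds with values here, compound 2 `CC(=O)O[C@@H]1[C@@H](F)[C@@H](CSC(C)=O)O[C@H]1n1ccc(=O)[nH]c1=O` is the higher of the two numbers known so far in a functional assay on MCF7 cells (Homo sapiens) for cytotoxicity, with a stated time of 72 h (a higher number here means that more compound is tolerated, a lower number that less compound is tolerated), though its nearest neighbour, compound 1 `CC(=O)O[C@@H]1[C@@H](F)[C@@H](CSC(C)=O)O[C@H]1n1cc(C)c(=O)[nH]c1=O`, sits within the scatter of it. In this assay compound 1 gives 278000 nM and compound 2 gives 289000 nM. Within the data shown here, the only step measured between them, a 1.0-fold higher number from compound 1 to compound 2 (0.02 log units; within the scatter), changes nothing beyond the scatter. Compound 3 `CC(=O)O[C@@H]1[C@@H](F)[C@@H](CSC(C)=O)O[C@H]1n1cc(F)c(=O)[nH]c1=O` differs from compound 2 by fluoro in place of hydrogen on an aromatic carbon. Among the measured compounds shown here, the one step that bears on this position, a 1.0-fold higher number from compound 1 to compound 2 (0.02 log units; within the scatter), was flat, so a flat outcome in this assay is the only expectation the data support, with a wide range to allow for a substituent not yet seen. Compound 3 is therefore estimated at 250000 nM, within 60000 nM to 500000 nM, which means an expected step of a 1.2-fold lower number from compound 2 to compound 3 (0.06 log units; within the scatter).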

Compound 3, half-maximal cytotoxic concentration: 1370000 nM
Compound 3: the middle estimate sits 5.5-fold (0.74 log units) below what was measured, and the stated range ends below it.
By their numbers in this assay, from the lowest: compounds 1 and 2 (each within the scatter of the next); then compound 3.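

In this assay the position proves not to be indifferent to what it carries: hydrogen and methyl on this aromatic carbon lie within the scatter of each other, but fluoro gives a clear departure from both (a 4.7-fold higher number from compound 2 to compound 3 (0.68 log units; beyond the scatter); a 4.9-fold higher number from compound 1 to compound 3 (0.69 log units; beyond the scatter)). Both steps lie beyond the scatter and run the same way, so the flat step seen earlier does not hold for every small group here, and more of compound 3 is tolerated than of either compound 1 or compound 2. No evidence is available to explain this departure.

Going by these compounds, whether chloro, bromo, an amine or a nitrile on this carbon would side with fluoro or with hydrogen and methyl remains open. So does whether the fluoro step would persist if the acetyl groups on the shared core gave way to free hydroxyl or thiol groups.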